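This account rests on a few compounds, and the source may have more. Where it says the series, first, only, none or still open, it means among the compounds named here.

Notes on the series, read in an ADME assay on H9c2 cells (Rattus norvegicus) for cytotoxicity; a higher number here means a weaker inhibitor, a lower number a stronger inhibitor. Compound 1 `O=C(Nc1nc2cccc(Cl)c2s1)C1CC1` gives > 50000 nM, which is a limit of the assay and not a number. Compound 2 `CN(C(=O)C1CC1)c1nc2ccc(Cl)cc2s1` gives > 50000 nM, and this too is a limit. Both results so far therefore sit in one place, (the limit of > 50000 nM in this assay, at which 2 of the 2 values shown sit), and compound 2 offers no exact value from which to count a step.

The next compound is compound 3 `O=C(C1CC1)N(CCO)c1nc2ccc(Cl)cc2s1`. The structural change is hydroxymethyl in place of hydrogen on a saturated chain carbon bound to an amide-type nitrogen, which can also be read as methyl to 2-hydroxyethyl. Among the measured compounds shown here, no measured step covers this change, so its size cannot be read from the data. The expectation rests on compound 2 at > 50000 nM. No step beyond the usual scatter is expected in this assay, and neither direction is favoured. The estimated step is a number no higher from compound 2 to compound 3 (the limit leaves the size open), and the assay is expected to report another limit rather than a number. For compound 3 the estimated value is 50000 nM, with an expected range from 25000 nM to 100000 nM.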

Compound 3, half-maximal inhibitory concentration: > 50000 nM
Compound 3 was reported as a limit (the forecaster's own chance of this, stated with the estimate: 80%); the middle value lies on the limit itself.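

In this assay no step can be read from compound 2 to compound 3, since the results for both are limits of the assay and not numbers: the limit of > 50000 nM in this assay, at which 3 of the 3 values shown sit.

The compounds shown leave open how large the effect of hydroxymethyl in place of hydrogen is, and which change to the shared core would give an exact number in this assay.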